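From fluoromethyl to iodomethyl on a shared core

This account rests on a few compounds, and the source may have more. Where it says the series, first, only, none or still open, it means among the compounds named here.

Measured in a functional assay on KB cells (Homo sapiens) for inhibition; on this read-out lower numbers stand for stronger inhibition and higher numbers for weaker inhibition:
- compound 1 `COC[C@H]1O[C@@H](n2c(Cl)nc3cc(Cl)c(Cl)cc32)[C@H](OC(C)=O)[C@@H]1OC(C)=O` gives 80000 nM
- compound 2 `CCCCOC[C@H]1O[C@@H](n2c(Cl)nc3cc(Cl)c(Cl)cc32)[C@H](OC(C)=O)[C@@H]1OC(C)=O` gives > 100000 nM as a limit of the assay
- compound 3 `CC(=O)OC1C(CF)OC(n2c(Cl)nc3cc(Cl)c(Cl)cc32)C1OC(C)=O` gives 100000 nM

Compound 3 at 100000 nM and compound 1 at 80000 nM lie within the scatter of each other, so both show only weak inhibition. Compound 4 `CC(=O)OC1C(CI)OC(n2c(Cl)nc3cc(Cl)c(Cl)cc32)C1OC(C)=O` carries iodo in place of fluoro on a saturated chain carbon bound to a saturated ring carbon. For the measured compounds named here, the only measured step is an at least 1.2-fold higher number from compound 1 to compound 2 (0.09 log units; that floor lies within the scatter) and it changes another group at another place, so it offers only a loose guide. The expected change in this assay is therefore small, and the estimated move is a 1.4-fold lower number from compound 3 to compound 4 (0.15 log units; within the scatter) without a clear direction beyond the scatter. Compound 4 is estimated at 70000 nM with an expected range from 25000 nM to 100000 nM in this estimate.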

Compound 4, half-maximal inhibitory concentration: 60000 nM
For compound 4 the middle estimate is 1.2-fold (0.07 log units) above the measured one, within the range that was stated.
By their numbers in this assay, from the lowest: compounds 4, 1 and 3 (each within the scatter of the next).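

In this assay the change from fluoro to iodo on this saturated chain carbon gives a 1.7-fold lower number from compound 3 to compound 4 (0.22 log units; within the scatter) and so stays within the scatter. Unlike the earlier compounds, this pair compares two halogens at one position, and inhibition remains weak with either on the shared core. These readings also lie close to the top of what is read here: the limit of > 100000 nM in this assay, at which 1 of the 4 values shown sits.

Going by these compounds, whether an amine or a carboxylic acid at this position would move the number beyond the scatter stays open. So does whether any group here could bring strong inhibition.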